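From urea to amide: what compound 4 may show

The source may report more compounds than this note shows. Statements on the series, on what has been measured and on what is new or still open speak of the compounds shown alone.

Measured so far, in a functional assay on SK-MEL-5 cells (Homo sapiens) for inhibition, read by sulforhodamine B assay, with a stated time of 48 h; a lower number here means a stronger inhibitor of growth, a higher number a weaker inhibitor of growth:
Compound 1 `O=C(Nc1cccc(-n2cc(-c3ccncc3)c(-c3ccc(Cl)c(O)c3)n2)c1)Nc1cccc(C(F)(F)F)c1` gives 4710 nM.
Compound 2 `COc1cc(-c2nn(-c3cccc(NC(=O)Nc4ccc(Cl)c(Cl)c4)c3)cc2-c2ccncc2)ccc1Cl` gives 1490 nM.
Compound 3 `COc1cc(-c2nn(-c3cccc(NC(=O)Nc4cccc(C(F)(F)F)c4)c3)cc2-c2ccncc2)ccc1Cl` gives 1390 nM.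

Compound 3 has the lowest of the three numbers in this assay, but compound 2 sits so close that the two cannot be told apart; only compound 1 is clearly separated, as a 3.4-fold lower number from compound 1 to compound 3 (0.53 log units; beyond the scatter) shows. The swap of the aryl group on the urea nitrogen, a 1.1-fold lower number from compound 2 to compound 3 (0.03 log units; within the scatter), changed nothing beyond the scatter.

Compound 4 `COc1cc(-c2nn(-c3cccc(NC(=O)c4ccccc4)c3)cc2-c2ccncc2)ccc1Cl` is made from compound 3 by the change (phenyl in place of (3-(trifluoromethyl)phenyl)amino on a carbonyl carbon). This turns the urea into a simple amide and drops the hydrogen-bond donor of the departing group. Neither measured step touches this part of the molecule in the same way: the step from compound 1 to compound 3 concerns the methyl on the ring oxygen, and the step from compound 2 to compound 3 only exchanges one aryl group for another while keeping the urea. The data therefore give no direct guide, and the expectation rests on the change itself being larger than either measured one.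

Compound 4 is expected to be a somewhat weaker inhibitor of growth in this assay, with an estimate of 4000 nM (range 1400 nM to 12000 nM), a step of a 2.9-fold higher number from compound 3 to compound 4 (0.46 log units; beyond the scatter).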

Compound 4, concentration for total growth inhibition: 1380 nM
Estimate against measurement, compound 4: 2.9-fold (0.46 log units) above, outside the stated range (below it).
By their numbers in this assay, from the lowest: compounds 4, 3 and 2 (each within the scatter of the next); then compound 1.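

In this assay, phenyl in place of (3-(trifluoromethyl)phenyl)amino on the carbonyl carbon gives a 1.0-fold lower number from compound 3 to compound 4 (0.00 log units; within the scatter), and phenyl in place of (3,4-dichlorophenyl)amino gives a 1.1-fold lower number from compound 2 to compound 4 (0.03 log units; within the scatter), so the ureas and the simple amide cannot be told apart here. Among these compounds, the earlier compounds showed only that one aryl group could be exchanged for another while the urea stayed in place; these steps go further, since the group that leaves carries a hydrogen-bond donor and the group that enters carries none, yet neither step lies beyond the scatter. No measurement at hand bears on why this result came out as it did.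

The compounds shown leave open whether anything on this carbonyl carbon other than phenyl or an arylamino group would fit equally well, such as a methyl group, a longer chain or a piperidine ring. They also leave open whether the amide would match the urea when the ring oxygen carries hydrogen, as it does in compound 1, instead of methyl.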